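Removing the Methyl from Compound 2's Amino Nitrogen

This account rests on a few compounds, and the source may have more. Where it says the series, first, only, none or still open, it means among the compounds named here.

Measured so far in a functional assay on Vero cells (Chlorocebus sabaeus) for inhibition; on this read-out higher numbers stand for weaker inhibition and lower numbers for stronger inhibition:
- Compound 1 `Nc1nc(F)nc2c1ncn2[C@@H]1CS[C@@H](CO)O1`: 45400 nM
- Compound 2 `CNc1ncnc2c1ncn2[C@@H]1CS[C@@H](CO)O1`: > 100000 nM

Compound 2 has no exact number, only a limit of the assay, and it gives > 100000 nM in this assay. Going by the values given here, that limit is the only one among the measured compounds: the limit of > 100000 nM in this assay, at which 1 of the 2 values shown sits.

The next compound is compound 3 `Nc1ncnc2c1ncn2[C@@H]1CS[C@@H](CO)O1`, which changes one small feature of compound 2: hydrogen in place of methyl on a nitrogen on an aromatic ring. In words, hydrogen takes the place of methyl on a nitrogen on an aromatic ring, turning methylamino to amino.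

Among the compounds with values here, no measured pair isolates this change. Compound 1 also carries the amino group, but it differs in having a fluorine as well, and it gives 45400 nM. A modest move towards stronger inhibition therefore seems likely. The expected change is an at least 1.6-fold lower number from compound 2 to compound 3 (0.22 log units; that floor lies within the scatter), though the result may stay at the limit.

For compound 3 the estimated value is 60000 nM, with an expected range from 15000 nM to 150000 nM.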

Compound 3, half-maximal inhibitory concentration: > 100000 nM
Compound 3 was reported as a limit (the forecaster's own chance of this, stated with the estimate: 45%); middle value at least 1.6-fold (0.22 log units) from the limit.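

In this assay, compound 3 gives > 100000 nM, which is a limit of the assay rather than a number, so the step for hydrogen in place of methyl on the aromatic-ring nitrogen cannot be read: the limit of > 100000 nM in this assay, at which 2 of the 3 values shown sit.

The new information concerns the fluoro on the aromatic carbon. Going by these compounds alone, replacing it with hydrogen gives an at least 2.2-fold higher number from compound 1 to compound 3 (0.34 log units; beyond the scatter), so in this one pair the fluoro goes with stronger inhibition, a link the earlier compounds could not isolate.

Still open, on these data alone, is whether another group at that aromatic carbon, such as chloro or methoxy, would give stronger inhibition than fluoro. A compound carrying both fluoro and methylamino could also show whether the methyl matters when the value is a number rather than a limit.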